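Aryl for cycloalkyl at the benzylamide ring: compound 3

The source may hold more compounds than are shown below. What is called first, only, known or untested is meant among the compounds shown, and "the series" means these compounds.

Measured so far:
compound 1 `CC(C(=O)NCc1ccc(C(F)(F)F)cc1Cl)c1ccc(NS(C)(=O)=O)c(F)c1` — 4 nM
compound 2 `CC(C(=O)NCc1ccc(C(F)(F)F)cc1C1CCCCC1)c1ccc(NS(C)(=O)=O)c(F)c1` — 0.6 nM

Both measured compounds were run in an assay on CHO cells for antagonist activity at transient receptor potential cation channel subfamily V member 1 (Homo sapiens), read by FLIPR; on this read-out higher numbers stand for weaker inhibition and lower numbers for stronger inhibition. Compound 2 holds the lowest number of the two, with compound 1 nearest; the step of a 6.7-fold lower number from compound 1 to compound 2 (0.82 log units; beyond the scatter) lies beyond the scatter.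

Compound 3 `CC(C(=O)NCc1ccc(C(F)(F)F)cc1-c1cccc(F)c1)c1ccc(NS(C)(=O)=O)c(F)c1` follows from compound 2 by 3-fluorophenyl in place of cyclohexyl on an aromatic carbon.

Among the measured compounds shown here, only one measured step touches this position, the exchange of chloro for cyclohexyl, which gave a 6.7-fold lower number from compound 1 to compound 2 (0.82 log units; beyond the scatter). For the measured compounds named here, no measured pair compares a cyclohexyl with a 3-fluorophenyl at this place, so the size of the present step is unknown; a group of similar size is kept there. The expectation is therefore a number close to that of compound 2, with a possible small rise, so compound 3 is expected to show a 1.7-fold higher number from compound 2 to compound 3 (0.22 log units; within the scatter) in this assay.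

Estimated for compound 3: 1 nM, range 0.3 nM to 4 nM.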

Compound 3, inhibition constant: 1.9 nM
Compound 3: middle estimate off by 1.9-fold (0.28 log units), on the low side; measured number inside the range.
By their numbers in this assay, from the lowest: compound 2; then compound 3; then compound 1.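

In this assay, this position on the aromatic ring distinguishes between two six-membered rings: the change to an aromatic ring gives a 3.2-fold higher number from compound 2 to compound 3 (0.50 log units; beyond the scatter) and so does not fully match cyclohexyl. The advantage over chloro is partly kept, with a 2.1-fold lower number from compound 1 to compound 3 (0.32 log units; beyond the scatter), so both ring-bearing compounds give lower numbers than compound 1, while compound 2 remains lower than compound 3. Nothing at hand accounts for the difference between the cyclohexyl and 3-fluorophenyl groups.

Still open, going by these compounds, is what the fluorine of the 3-fluorophenyl group contributes, which a plain phenyl group at this place would show. Also open, on these data alone, is whether a cyclopentyl ring or a piperidine, with its ring nitrogen, would give a number near that of compound 2.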